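The source may report more compounds than this note shows. Statements on the series, on what has been measured and on what is new or still open speak of the compounds shown alone.

Measured so far in an ADME assay on microsomes from liver (Mus musculus) for metabolic stability; on this read-out higher numbers stand for fast clearance and lower numbers for slow clearance:

Compound 1, `COc1cc([C@](O)(CCN(C)C)[C@@H](c2cc3cc(Br)ccc3nc2OC)c2cccc(OC)c2F)cc(OC(C)C)n1`, 6 uL/min
Compound 2, `COc1cc([C@](O)(CCN(C)C)[C@@H](c2cc3cc(Br)ccc3nc2OC)c2ccnc(OC)c2OC)cc(OC(C)C)n1`, 6.7 uL/min
Compound 3, `COc1cc([C@](O)(CCN(C)C)[C@@H](c2cc3cc(C#N)ccc3nc2OC)c2ccnc(OC)c2OC)cc(OC(F)F)n1`, 11 uL/min

Compound 1 gives the lowest of the three numbers in this assay, but its gaps to compound 2 and to compound 3 are both within the scatter, so the three compounds cannot be ordered against one another.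

Compound 4, `COc1cc([C@](O)(CCN(C)C)[C@@H](c2cc3cc(Br)ccc3nc2OC)c2cccc(OC)c2F)cc(SC)n1`, has not been measured. It differs from compound 1 in one place: methylsulfanyl in place of isopropoxy on an aromatic carbon.

Among the compounds with values here, only one single-place step has been measured, a 1.1-fold higher number from compound 1 to compound 2 (0.05 log units; within the scatter), and it concerns the substituent on the saturated chain carbon, not the aromatic carbon on the ring with one nitrogen where the present change sits. Within the data shown here, compound 3 differs from compound 1 in several places at once, so its value shows only that a different group on this carbon, among other changes, still gave a number within the scatter of compound 1. Among the measured compounds shown here, there is thus no measured step that directly tests methylsulfanyl in place of isopropoxy; what has been seen at other places has stayed within the scatter.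

Compound 4 is therefore expected to remain close to compound 1 in this assay, with an estimated step of a 1.2-fold higher number from compound 1 to compound 4 (0.07 log units; within the scatter), and an estimated value of 7 uL/min, in the range 3.5 uL/min to 14 uL/min.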

Compound 4, intrinsic clearance in a liver preparation (reported as CLH), per the amount of preparation that the assay uses: 20 uL/min
The estimate for compound 4 lay 2.9-fold (0.46 log units) below the measured number, and the stated range ends below it.
By their numbers in this assay, from the lowest: compounds 1, 2, 3 and 4 (each within the scatter of the next, the first and the last beyond it).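

In this assay, within the data shown here, the aromatic carbon next to the ring nitrogen is the first place where a single change carries the number beyond the scatter: methylsulfanyl in place of isopropoxy gives a 3.3-fold higher number from compound 1 to compound 4 (0.52 log units; beyond the scatter), a modest step. Among these compounds, the only other single-place step, a 1.1-fold higher number from compound 1 to compound 2 (0.05 log units; within the scatter), concerns the saturated chain carbon and stays within the scatter, so this ring position cannot be treated as silent in the way the earlier numbers allowed. No measurement at hand gives a reason for the step.

The change replaces the oxygen with sulfur and the isopropoxy chain with a smaller group at once, so the step cannot be assigned to either part; an isopropylsulfanyl group at this carbon would set the two apart. Also open, from the compounds shown here alone, is whether the same step appears with 2,3-dimethoxypyridin-4-yl in place of 2-fluoro-3-methoxyphenyl on the saturated chain carbon, and how an amine at this ring position would read in this assay.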